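Chloro in place of methyl on the core of compound 3

A few compounds are considered here, and "the series" means these few. Any claim that something is new, unique, unknown or untested is made for them only; others in the source may bear on it.

Three measured compounds share one core and differ only in a single group on a six-membered ring of carbon only. In a functional assay on the whole organism for inhibition, with Rattus norvegicus as the target, at a dose of 30 mg/kg (a lower number here means less inhibition, a higher number more inhibition at the dose given (going by the name of the read-out)), compound 1 `N#Cc1ccccc1-c1nc2cccnc2o1` gives 61%. Compound 2 `c1ccc(-c2nc3cccnc3o2)cc1` gives 55% in this assay, and the step of a number 6 percentage points lower from compound 1 to compound 2 (within the scatter) lies within the scatter, so these two cannot be ranked against each other. Compound 3 `Cc1ccccc1-c1nc2cccnc2o1` gives 3% in this assay and stands lowest of the three numbers; the steps of a number 58 percentage points lower from compound 1 to compound 3 (beyond the scatter) and a number 52 percentage points lower from compound 2 to compound 3 (beyond the scatter) are both large and beyond the scatter.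

Compound 4 `Clc1ccccc1-c1nc2cccnc2o1` has not yet been measured in this assay. It differs from compound 3 by chloro in place of methyl on an aromatic carbon. For the measured compounds named here, no measured step brings in chloro, so the only guide is that hydrogen and cyano at this carbon gave numbers within the scatter of each other, while methyl alone fell far below them. Compound 4 is expected to recover part of that loss because the step of a number 52 percentage points lower from compound 2 to compound 3 (beyond the scatter) was large and the step of a number 6 percentage points lower from compound 1 to compound 2 (within the scatter) was small, but the size is uncertain. Compound 4 is therefore estimated at 25%, with a range from 0% to 60%. The expected step of a number 22 percentage points higher from compound 3 to compound 4 (beyond the scatter) is a rise of uncertain size.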

Compound 4, a percentage reported as inhibition, in the whole organism at one dose (the size of the read-out at that dose, not a potency): 50%
Beside the measured number, compound 4's estimate is 25 percentage points below it; the measured number falls inside the stated range.
By their numbers in this assay, from the lowest: compound 3; then compounds 4, 2 and 1 (each within the scatter of the next, the first and the last beyond it).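

In this assay, chloro in place of methyl gives a number 47 percentage points higher from compound 3 to compound 4 (beyond the scatter) and so shows that the loss seen with methyl does not extend to every other group of this size: both groups have 1 heavy atom and neither has a hydrogen-bond donor or acceptor, so these counts alone do not separate the two compounds. Chloro in place of hydrogen gives a number 5 percentage points lower from compound 2 to compound 4 (within the scatter) and leaves these two groups unranked, while chloro in place of cyano gives a number 11 percentage points lower from compound 1 to compound 4 (beyond the scatter) as a modest step, so among the groups at this carbon, methyl remains the one clear outlier on the low side. Nothing shown here offers a measured explanation for the way methyl stands apart from chloro, hydrogen and cyano.

Still open, as far as these compounds go, is how ethyl, methoxy, fluoro or an amine on this same aromatic carbon would compare, and so whether the low number belongs to methyl alone or to a wider set of groups. Also open, from the compounds shown here alone, is whether chloro would keep such a number on the other carbons of this six-membered aromatic ring.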